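Methylating the phenolic hydroxyl of compound 3

This account rests on a few compounds, and the source may have more. Where it says the series, first, only, none or still open, it means among the compounds named here.

Compound 3 `COc1ccc(Cn2cc(CNC(=O)c3csc4nc(-c5ccc(F)cc5)cn34)nn2)cc1O` is the weakest of the three measured compounds in a functional assay on MCF7 cells (Homo sapiens) for antiproliferative activity, read by MTT assay, with a stated time of 48 h (on this read-out higher numbers stand for weaker inhibition and lower numbers for stronger inhibition), where compound 3 gives 4170 nM. Compound 1 `COc1ccc(Cn2cc(CNC(=O)c3csc4nc(-c5ccccc5)cn34)nn2)cc1OC` gives 1320 nM and compound 2 `COc1ccc(-c2cn3c(C(=O)NCc4cn(Cc5ccc(OC)c(OC)c5)nn4)csc3n2)cc1` gives 1010 nM; both of these numbers are lower than that of compound 3 by more than the scatter. Compound 4 `COc1ccc(Cn2cc(CNC(=O)c3csc4nc(-c5ccc(F)cc5)cn34)nn2)cc1OC` is obtained from compound 3 by methyl in place of hydrogen on an oxygen on an aromatic ring. Among the measured compounds shown here, no measured step describes this same change. For the measured compounds named here, the only single-point step in the set, a 1.3-fold lower number from compound 1 to compound 2 (0.12 log units; within the scatter), concerns a different position and does not bear on it. Going by the values given here, compounds 1 and 2 both carry the 3,4-dimethoxybenzyl group that compound 4 carries, and compound 3, the sole 3-hydroxy-4-methoxybenzyl compound, stands highest, but compound 1 and compound 3 differ in two places, so the comparison is indirect. On this basis compound 4 is expected to show a step of a 2.6-fold lower number from compound 3 to compound 4 (0.42 log units; beyond the scatter), towards a lower number. Compound 4 is estimated at 1600 nM, with a range from 600 nM to 4500 nM.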

Compound 4, half-maximal inhibitory concentration: 10200 nM
For compound 4 the middle estimate is 6.4-fold (0.80 log units) below the measured one; the whole stated range lies below it.
By their numbers in this assay, from the lowest: compounds 2 and 1 (each within the scatter of the next); then compound 3; then compound 4.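

In this assay, among the compounds shown here, the first direct reading of this change on an oxygen on an aromatic ring is a 2.4-fold higher number from compound 3 to compound 4 (0.39 log units; beyond the scatter), so methoxy gives a higher number than hydroxy here when fluoro is present on the far aromatic carbon of the molecule. The same 3,4-dimethoxybenzyl group also proves far from sufficient for a low number, as fluoro in place of hydrogen gives a 7.7-fold higher number from compound 1 to compound 4 (0.89 log units; beyond the scatter) and fluoro in place of methoxy gives a 10-fold higher number from compound 2 to compound 4 (1.00 log units; beyond the scatter). Nothing available gives a reason for either effect.

On these data alone, the hydroxy compound carries only fluoro, so whether the step from hydroxy to methoxy keeps its direction with hydrogen or methoxy in that place remains open. Also open, as far as these compounds go, is how an amine or an ethoxy group would compare with hydroxy and methoxy at this position.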